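This account rests on a few compounds, and the source may have more. Where it says the series, first, only, none or still open, it means among the compounds named here.

In a functional assay on MDCK cells (Canis lupus familiaris) for antiproliferative activity (a lower number here means a stronger inhibitor, a higher number a weaker inhibitor), compound 3 `CC1=C(CC(=O)O)c2cc(F)ccc2/C1=C\c1cccs1` gives 80000 nM, the lowest of the two single numbers in this set. Going by the values given here, its nearest neighbour is compound 1 `COc1ccccc1/C=C1/C(C)=C(CC(=O)O)c2cc(F)ccc21`, which in this assay gives 360000 nM; the swap of 2-methoxyphenyl for thiophen-2-yl on the double-bonded chain carbon is the only resolved step, a 4.5-fold lower number from compound 1 to compound 3 (0.65 log units; beyond the scatter). Compound 2 `CC1=C(CC(=O)O)c2cc(F)ccc2/C1=C\c1ccc(C)o1` has several entries in this assay, 310000 nM; 60000 nM (2 entries), and these scatter too widely to give one number (the several entries of compound 2 in this assay, 310000 nM; 60000 nM (2 entries)).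

Compound 4 `CC1=C(CC(=O)O)c2cc(F)ccc2/C1=C\c1ccoc1` is the next member: furan-3-yl in place of thiophen-2-yl on a double-bonded chain carbon bound to a double-bonded ring carbon. Among the compounds with values here, the single step that bears on this change is the aryl exchange at the same place from compound 1 to compound 3, which was modest in size and pointed downward. A change between two five-membered aromatic rings with one hetero atom each is smaller in kind than that one, so no step beyond the scatter is expected, with the chance of a slight rise for compound 4 allowed for in the range. The expected step is a 1.4-fold higher number from compound 3 to compound 4 (0.14 log units; within the scatter). For compound 4 in this assay the estimate is 110000 nM, with a range from 35000 nM to 350000 nM.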

Compound 4, half-maximal inhibitory concentration: 50000 nM
For compound 4 the middle estimate is 2.2-fold (0.34 log units) above the measured one, within the range that was stated.
By their numbers in this assay, from the lowest: compounds 4 and 3 (each within the scatter of the next); then compound 1.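

In this assay, thiophen-2-yl and furan-3-yl are not separated on the double-bonded chain carbon bound to a double-bonded ring carbon (a 1.6-fold lower number from compound 3 to compound 4 (0.20 log units; within the scatter)). The 2-methoxyphenyl group now stands apart from two different five-membered aromatic rings, not just one (a 7.2-fold lower number from compound 1 to compound 4 (0.86 log units; beyond the scatter)), so the earlier step is not specific to thiophen-2-yl. Steps involving compound 2 cannot be read, so it neither supports nor goes against this reading: (the several entries of compound 2 in this assay, 310000 nM; 60000 nM (2 entries)).

Thiophen-3-yl would show whether the hetero atom or the ring attachment matters at this place, as the step to compound 4 changes both. Also open, going by these compounds, is what an aryl group carrying an amine would give there, and whether an amide in place of the carboxylic acid would move the numbers.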